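A few compounds are considered here, and "the series" means these few. Any claim that something is new, unique, unknown or untested is made for them only; others in the source may bear on it.

Going by the values given here, compound 3 `O=C(O)CCCC/C=C(/c1cccnc1)c1ccsc1` gives 62 nM in an assay (Equus caballus) for inhibition of Thromboxane-A synthase (Homo sapiens), using microsomes (a higher number here means a weaker inhibitor, a lower number a stronger inhibitor), the highest of the three numbers measured so far. Compound 1 `O=C(O)C(CCC/C=C(/c1cccnc1)c1cccs1)c1ccccc1` gives 32 nM in this assay, and compound 2 `O=C(O)CCCC/C=C(\c1cccnc1)c1ccsc1` gives 31 nM; both gaps to compound 3 lie within the scatter, so no order among the three can be read from them. Among the compounds with values here, the only step between compounds that differ in one place is a 2.0-fold higher number from compound 2 to compound 3 (0.30 log units; within the scatter), and the fact that compounds 2 and 3 differ only in the configuration as drawn is all that stands behind it. Compound 4 `O=C(O)CCCC/C=C(/c1cccnc1)c1cccs1` differs from compound 3 by thiophen-2-yl in place of thiophen-3-yl on a double-bonded chain carbon bound to an aromatic carbon and a double-bonded chain carbon. Within the data shown here, no measured step touches this exchange directly; compound 1 carries thiophen-2-yl but differs from compound 3 elsewhere as well, so its value and that of compound 3 can only be set side by side, and they lie within the scatter of each other. Among the measured compounds shown here, with the single measured step itself within the scatter, the expected change is small, a 1.4-fold lower number from compound 3 to compound 4 (0.14 log units; within the scatter), with no firm direction. Compound 4 is therefore estimated at 45 nM, between 20 nM and 100 nM.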

Compound 4, half-maximal inhibitory concentration: 54 nM
Estimate against measurement, compound 4: 1.2-fold (0.08 log units) below, within the range that was stated.
By their numbers in this assay, from the lowest: compounds 2, 1, 4 and 3 (each within the scatter of the next).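

On a double-bonded chain carbon bound to an aromatic carbon and a double-bonded chain carbon, the exchange of thiophen-3-yl for thiophen-2-yl now has a step of its own in this assay, and it shows a 1.1-fold lower number from compound 3 to compound 4 (0.06 log units; within the scatter). On a saturated chain carbon bound to a carbonyl carbon and a saturated chain carbon, hydrogen in place of phenyl shows a 1.7-fold higher number from compound 1 to compound 4 (0.23 log units; within the scatter), so neither exchange moves the number beyond the scatter. Nothing at hand gives a reason for either step.

From the compounds shown here alone, whether furan-2-yl on the double-bonded chain carbon would also stay within the scatter remains open. So does the effect of a methyl group or a longer chain on the saturated chain carbon.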